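This account rests on a few compounds, and the source may have more. Where it says the series, first, only, none or still open, it means among the compounds named here.

Measured compounds:
compound 1 `CNc1nc(C#Cc2ccccc2)nc2c1ncn2[C@H]1[C@H](O)[C@H](O)[C@@H]2C[C@@H]21`, 5.48 nM
compound 2 `CONc1nc(C#Cc2ccccc2)nc2c1ncn2[C@H]1[C@H](O)[C@H](O)[C@@H]2C[C@@H]21`, 13 nM
compound 3 `CCNc1nc(C#Cc2ccccc2)nc2c1ncn2[C@H]1[C@H](O)[C@H](O)[C@@H]2C[C@@H]21`, 5.02 nM

In an assay on CHO cells for displacement of a labelled ligand from adenosine receptor A3 (Homo sapiens), read by scintillation counting, with a stated time of 60 min (on this read-out lower numbers stand for stronger inhibition and higher numbers for weaker inhibition), compound 3 gives the lowest number of the three, though the step of a 1.1-fold lower number from compound 1 to compound 3 (0.04 log units; within the scatter) lies within the scatter, so compound 1 and compound 3 cannot be set apart on these data; compound 2 stands away from both, as a 2.4-fold higher number from compound 1 to compound 2 (0.38 log units; beyond the scatter) and a 2.6-fold lower number from compound 2 to compound 3 (0.41 log units; beyond the scatter) show.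

Compound 4 `O[C@@H]1[C@H](O)[C@@H]2C[C@@H]2[C@H]1n1cnc2c(NCc3cccc(Cl)c3)nc(C#Cc3ccccc3)nc21` is not yet measured. The change from compound 3 is 3-chlorophenyl in place of methyl on a saturated chain carbon bound to a nitrogen on an aromatic ring, that is, ethylamino becomes (3-chlorobenzyl)amino. Going by the values given here, the only measured step at the same place is a 1.1-fold lower number from compound 1 to compound 3 (0.04 log units; within the scatter), a change of one carbon that left the number essentially unmoved; the steps involving compound 2 concern the nitrogen itself and do not test a larger group on the chain carbon. Among the compounds with values here, no step of this size has been measured, so the direction is uncertain. A small step is expected, a 1.7-fold lower number from compound 3 to compound 4 (0.22 log units; within the scatter), with a wide range. For compound 4 the estimate in this assay is 3 nM, between 0.8 nM and 12 nM.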

Compound 4, inhibition constant: 39 nM
Beside the measured number, compound 4's estimate is 13-fold (1.11 log units) below it; measured number above the stated range.
By their numbers in this assay, from the lowest: compounds 3 and 1 (each within the scatter of the next); then compound 2; then compound 4.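

In this assay, the saturated chain carbon bound to a nitrogen on an aromatic ring proves sensitive to the change: 3-chlorophenyl in place of methyl gives a 7.8-fold higher number from compound 3 to compound 4 (0.89 log units; beyond the scatter), whereas the one-carbon change gave only a 1.1-fold lower number from compound 1 to compound 3 (0.04 log units; within the scatter). The (3-chlorobenzyl)amino group also falls behind the smaller methylamino group, with a 7.1-fold higher number from compound 1 to compound 4 (0.85 log units; beyond the scatter), and behind the methoxy group on the same nitrogen, with a 3.0-fold higher number from compound 2 to compound 4 (0.48 log units; beyond the scatter), so the flat response seen from methyl to ethyl does not extend to this group. Nothing available accounts for this rise in the number.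

On these data alone, whether the rise belongs to the phenyl ring or to the chlorine remains open, and an unsubstituted benzyl group would separate the two. A propyl or longer alkyl chain would show whether a group without a ring also raises the number.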